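This account rests on a few compounds, and the source may have more. Where it says the series, first, only, none or still open, it means among the compounds named here.

Measured so far:
compound 1 `OC[C@H](NC1CCN(CCCc2c[nH]c3ccc(-n4ccnc4)cc23)CC1)c1ccccc1`: 0.8 nM
compound 2 `O[C@@H]1Cc2ccccc2[C@H]1NC1CCN(CCCc2c[nH]c3ccc(-n4cnnc4)cc23)CC1`: 13 nM

In an assay on CHO cells for agonist activity at 5-hydroxytryptamine receptor 1D (Homo sapiens), read by GTPgammaS binding (a higher number here means that more compound is needed for the effect, a lower number that less compound is needed), compound 2 gives the higher of the two numbers, and compound 1 gives a much lower one. Compound 3 `NC(=O)OC[C@H](NC1CCN(CCCc2c[nH]c3ccc(-n4cnnc4)cc23)CC1)c1ccccc1` differs from compound 2 by 2-(carbamoyloxy)-1-phenylethyl in place of 2-hydroxy-2,3-dihydro-1H-inden-1-yl on an amine nitrogen. Among the compounds with values here, no step between measured compounds has been traced, so the direction rests on resemblance: the side chain of compound 3 is close to that of compound 1, which gives 0.8 nM in this assay. A step down in number beyond the scatter is expected, of the size a 4.3-fold lower number from compound 2 to compound 3 (0.64 log units; beyond the scatter). Compound 3 is therefore estimated at 3 nM, within a range from 0.8 nM to 12 nM.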

Compound 3, half-maximal effective concentration: 9.3 nM
Beside the measured number, compound 3's estimate is 3.1-fold (0.49 log units) below it; the measured number falls inside the stated range.
By their numbers in this assay, from the lowest: compound 1; then compounds 3 and 2 (each within the scatter of the next).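

In this assay, the amine nitrogen takes 2-(carbamoyloxy)-1-phenylethyl in place of 2-hydroxy-2,3-dihydro-1H-inden-1-yl with a 1.4-fold lower number from compound 2 to compound 3 (0.15 log units; within the scatter), so the two groups cannot be told apart at this position. For these two compounds, the five-membered non-aromatic ring and the second defined stereocentre are therefore not needed to keep a number of this size. No measurement shown offers an explanation for this result.

Compound 1 differs from compound 3 in more than one place, so the gap between their numbers cannot be assigned to either difference. Also open, going by these compounds, is how an amine or a carboxylic acid would read in place of the carbamoyloxy part of the side chain.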